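Swapping a cyanophenyl for a chlorofluorophenyl in compound 2

The source may hold more compounds than are shown below. What is called first, only, known or untested is meant among the compounds shown, and "the series" means these compounds.

In an assay on lysate for inhibition of phosphatidylcholine:ceramide cholinephosphotransferase 2 (Homo sapiens), read by HPLC, with stated times of 30 min and 2 h (on this read-out higher numbers stand for weaker inhibition and lower numbers for stronger inhibition), compound 1 `O=C(Nc1cccnc1)c1ccccc1OCc1ccccc1C(F)(F)F` gives 2100 nM, while compound 2 `N#Cc1ccccc1COc1ccccc1C(=O)Nc1cccnc1` gives 31800 nM. Among the compounds with values here, compound 2 thus stands as the weaker of the two measured compounds, its nearest neighbour being compound 1, and the one measured step, a 15-fold higher number from compound 1 to compound 2 (1.18 log units; beyond the scatter), is the only comparison that bears on what follows. Compound 3 `O=C(Nc1cccnc1)c1ccccc1OCc1cc(F)ccc1Cl` differs from compound 2 in a single place: 2-chloro-5-fluorophenyl in place of 2-cyanophenyl on a saturated chain carbon bound to an oxygen on an aromatic ring. The group that leaves is the same 2-cyanophenyl whose arrival in place of the trifluoromethyl-bearing ring went with the large loss seen in compound 2, and the group that enters carries no hydrogen-bond acceptor, as the trifluoromethyl ring of compound 1 also carried none. On that basis a step back in the stronger direction is expected from compound 2 to compound 3 in this assay, of a size beyond the scatter though not necessarily recovering all of the gap to compound 1, estimated as a 9.1-fold lower number from compound 2 to compound 3 (0.96 log units; beyond the scatter). Compound 3 is therefore expected to give about 3500 nM, within a range of 900 nM to 14000 nM.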

Compound 3, half-maximal inhibitory concentration: 740 nM
Estimate against measurement, compound 3: 4.7-fold (0.67 log units) above, and the stated range ends above it.
By their numbers in this assay, from the lowest: compound 3; then compound 1; then compound 2.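

In this assay, 2-chloro-5-fluorophenyl in place of 2-cyanophenyl on a saturated chain carbon bound to an oxygen on an aromatic ring gives a 43-fold lower number from compound 2 to compound 3 (1.63 log units; beyond the scatter), which shows that this position responds strongly to the ring it carries, in the stronger direction as well as the weaker. The earlier pair showed only a large loss on moving to the nitrile, whereas compound 3 at 740 nM now has a lower number than compound 1 at 2100 nM, so the trifluoromethyl-bearing ring does not mark the best result among the compounds shown. Nothing measured here bears on the reason for this large step.

Open remains which halogen accounts for the gain, since chlorine and fluorine enter together and no compound shown carries either one alone on the ring. Also open, going by these compounds, is how far the position tolerates other groups, such as a methoxy group, an amine or a carboxylic acid, and whether the same ring would behave alike if the oxygen-bound chain carbon were replaced by a longer chain.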